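A few compounds are considered here, and "the series" means these few. Any claim that something is new, unique, unknown or untested is made for them only; others in the source may bear on it.

Measured in a functional assay on HepG2 cells (Homo sapiens) for cytotoxicity, read by MTT assay, with a stated time of 48 h; on this read-out lower numbers stand for stronger inhibition and higher numbers for weaker inhibition
- compound 1 `CCN(CC)Cc1ccc2c(=O)cc(-c3ccc([N+](=O)[O-])cc3)oc2c1` gives "not determined" (no result reported)
- compound 2 `CCN(CC)Cc1cc(Cl)cc2c(=O)cc(-c3ccc([N+](=O)[O-])cc3)oc12` gives 1190 nM
- compound 3 `O=c1cc(-c2ccc([N+](=O)[O-])cc2)oc2c(CN3CCCCC3)cc(Cl)cc12` gives 8910 nM

Among the measured compounds shown here, compound 3 carries the higher of the two numbers so far, and compound 1 offers no number for comparison. The next compound to be tested is compound 4 `CN(C)Cc1cc(Cl)cc2c(=O)cc(-c3ccc([N+](=O)[O-])cc3)oc12`, which has dimethylamino in place of piperidin-1-yl on a saturated chain carbon bound to an aromatic carbon. The counted difference is dimethylamino in place of piperidin-1-yl on a saturated chain carbon bound to an aromatic carbon.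

For the measured compounds named here, one measured step bears on this change, at the same place: a 7.5-fold higher number from compound 2 to compound 3 (0.87 log units; beyond the scatter), where piperidin-1-yl replaced diethylamino. Going by the values given here, compound 4 reverses that ring-for-chain exchange, but with the smaller dimethylamino, and no dimethylamino compound has a measured value yet. A step toward a lower number is therefore expected, probably somewhat smaller than the measured one and still beyond the scatter. The expected step is a 4.5-fold lower number from compound 3 to compound 4 (0.65 log units; beyond the scatter). The estimate for compound 4 is 2000 nM, with an expected range of 700 nM to 6500 nM.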

Compound 4, half-maximal inhibitory concentration: 6190 nM
Estimate against measurement, compound 4: 3.1-fold (0.49 log units) below; the measured number falls inside the stated range.
By their numbers in this assay, from the lowest: compound 2; then compounds 4 and 3 (each within the scatter of the next).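

In this assay, dimethylamino in place of piperidin-1-yl on a saturated chain carbon bound to an aromatic carbon gives a 1.4-fold lower number from compound 3 to compound 4 (0.16 log units; within the scatter) and so does not separate the open-chain amine from the ring. Diethylamino now stands apart: dimethylamino in its place gives a 5.2-fold higher number from compound 2 to compound 4 (0.72 log units; beyond the scatter) and, with a 7.5-fold higher number from compound 2 to compound 3 (0.87 log units; beyond the scatter) for piperidin-1-yl, this leaves compound 2 with the lowest number of the three, so at this position the step follows neither the presence of a ring nor the heavy-atom count in any simple way. No measured evidence bears on the reason for this difference.

Going by these compounds, it remains open whether the low number of compound 2 is particular to diethylamino or extends to a longer chain such as dipropylamino. Rings such as pyrrolidin-1-yl or morpholin-4-yl could also fall on either side of the present gap.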